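A few compounds are considered here, and "the series" means these few. Any claim that something is new, unique, unknown or untested is made for them only; others in the source may bear on it.

Compound 1 `Cc1nc2ccc(-c3ccccc3Cl)c(CN)c2n1C`: > 3.33 h (a limit)
Compound 2 `CCn1cnc2ccc(-c3ccc(Cl)cc3Cl)c(CN)c21`: > 3.33 h (a limit)
Compound 3 `Cn1cnc2ccc(-c3ccccc3CO)c(CN)c21`: 1.67 h

These values come from an in vitro ADME assay on microsomes from liver (Homo sapiens) for metabolic stability; on this read-out lower numbers stand for a shorter-lived compound and higher numbers for a longer-lived compound. Compound 2 has no exact number, only the limit > 3.33 h. It thus sits at the limit of > 3.33 h in this assay, at which 2 of the 3 values shown sit. Compound 4 `NCc1c(-c2ccc(Cl)cc2Cl)ccc2nc[nH]c12` differs from compound 2 in one place: hydrogen in place of ethyl on an aromatic nitrogen. Among the compounds with values here, no measured pair isolates this change, so its size is uncertain. Compound 3 gives 1.67 h, which shows that measurable numbers do occur among these compounds. The expected step, an at least 1.1-fold lower number from compound 2 to compound 4 (0.04 log units; that floor lies within the scatter), is small and downward, probably none beyond the scatter. In this assay, compound 4 is estimated at 3 h, with an expected range of 1.5 h to 5.5 h.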

Compound 4, half-life: 2.15 h
Compound 4: the middle estimate sits 1.4-fold (0.14 log units) above what was measured; measured number inside the range.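

Compound 4 gives this position, an aromatic nitrogen of a five-membered aromatic ring, its first exact number, with hydrogen in place of ethyl. In this assay the change gives an at least 1.5-fold lower number from compound 2 to compound 4 (0.19 log units; that floor lies within the scatter), so a real drop is not established, although the true step may be larger. The step is only a floor because compound 2 carries a limit and not a number: the limit of > 3.33 h in this assay, at which 2 of the 4 values shown sit.

As far as these compounds go, how large the true step is stays open. So does whether propyl or cyclopropyl on that nitrogen would read like ethyl or like hydrogen.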